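The compounds below may be only part of what the source reports. "The series", "measured", "known", "first", "only" and "open" are said of these compounds alone.

Compound 3 `C=CCOC(=O)Nc1ccc([Se]C#N)cc1` carries the allyl carbamate of the shared core. Among the compounds with values here, in a functional assay on MCF7 cells (Homo sapiens) for cytotoxicity, read by MTT assay, with a stated time of 72 h (on this read-out higher numbers stand for weaker inhibition of growth and lower numbers for stronger inhibition of growth), compound 3 gives 15000 nM, the highest of the three numbers measured so far. Its nearest neighbour is compound 1 `CCCOC(=O)Nc1ccc([Se]C#N)cc1`, which in this assay gives 8000 nM; compound 2 `CCCCOC(=O)Nc1ccc([Se]C#N)cc1` gives 6600 nM in this assay. The step of a 1.9-fold higher number from compound 1 to compound 3 (0.27 log units; within the scatter) and the step of a 2.3-fold higher number from compound 2 to compound 3 (0.36 log units; beyond the scatter) both run toward higher numbers when the vinyl replaces a saturated alkyl on the chain carbon bound to the oxygen next to the carbonyl group, the second of them beyond the scatter. The step of a 1.2-fold lower number from compound 1 to compound 2 (0.08 log units; within the scatter) shows that lengthening the saturated chain by one methyl changes little.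

Compound 4 `CCOC(=O)Nc1ccc([Se]C#N)cc1` is the ethyl carbamate; it differs from compound 3 by methyl in place of vinyl on a saturated chain carbon bound to an oxygen next to a carbonyl group. Removing the double bond resembles the reverse of the two steps above, so the number for compound 4 in this assay is expected to fall modestly, by about a 1.7-fold lower number from compound 3 to compound 4 (0.22 log units; within the scatter), toward the region of compound 1. Compound 4 is therefore estimated at 9000 nM, with a range from 4500 nM to 18000 nM.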

Compound 4, concentration for 50% growth inhibition: 8900 nM
Estimate against measurement, compound 4: 1.0-fold (0.00 log units) above; measured number inside the range.
By their numbers in this assay, from the lowest: compounds 2, 1, 4 and 3 (each within the scatter of the next, the first and the last beyond it).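

In this assay, the change from allyl to ethyl on a saturated chain carbon bound to an oxygen next to a carbonyl group gives a 1.7-fold lower number from compound 3 to compound 4 (0.23 log units; within the scatter), so the double bond does not clearly separate this pair. The saturated series now has a third member, and with a 1.1-fold higher number from compound 1 to compound 4 (0.05 log units; within the scatter) and a 1.3-fold higher number from compound 2 to compound 4 (0.13 log units; within the scatter), the ethyl, propyl and butyl carbamates of compound 4, compound 1 and compound 2 cannot be told apart in this assay. Nothing available accounts for these values.

Going by these compounds, it remains open whether a much longer chain, a branched chain such as isopropyl or a benzyl group would move the number beyond the scatter. A terminal amine or carboxylic acid on the chain is likewise untested in these notes.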